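This account rests on a few compounds, and the source may have more. Where it says the series, first, only, none or still open, it means among the compounds named here.

Working notes on the series. In an ADME assay on BHK cells (Mesocricetus auratus) for cytotoxicity, read by MTT assay, with a stated time of 96 h (on this read-out higher numbers stand for lower toxicity in this test and lower numbers for higher toxicity in this test), compound 1 `FC(F)(F)c1cccc(NC(=S)Nc2cccc(Br)c2)c1` gives 10000 nM. In this assay compound 2 `CC[C@H]1CC[C@H](c2ccc(NC(=S)Nc3cccc(C(F)(F)F)c3)cc2)CC1` gives 10000 nM, and in this assay compound 3 `Fc1ccc(NC(=S)Nc2cccc(C(F)(F)F)c2)cc1Cl` gives 10000 nM. Compound 2 thus stands level with compound 1 and compound 3 at the digits recorded; its nearest neighbour on these numbers is compound 1 and its furthest is compound 3, and in both cases the difference lies within the scatter, so no order among the three is claimed. Compound 4 `CCCC[C@H]1CC[C@H](c2ccc(NC(=S)Nc3cccc(C(F)(F)F)c3)cc2)CC1` has not yet been run in this assay. It differs from compound 2 in one place: ethyl in place of hydrogen on a saturated chain carbon, two bonds along the chain from a saturated ring carbon. Going by the values given here, no step between measured compounds is available that would show how such a change reads in this assay, and the three measured values give no spread from which a direction could be taken. The step is expected to be none beyond the scatter, no change at the digits printed from compound 2 to compound 4 (within the scatter). Compound 4 is therefore expected to give about 10000 nM in this assay, with a range from 5000 nM to 20000 nM.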

Compound 4, half-maximal cytotoxic concentration: 9500 nM
For compound 4 the middle estimate is 1.1-fold (0.02 log units) above the measured one; the range from low to high includes it.
By their numbers in this assay, from the lowest: compounds 4, 1, 2 and 3 (each within the scatter of the next).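

In this assay, going by these compounds alone, ethyl in place of hydrogen on a saturated chain carbon, two bonds along the chain from a saturated ring carbon, gives a 1.1-fold lower number from compound 2 to compound 4 (0.02 log units; within the scatter) and is the first step that can be read at this position. The change from 4-ethylcyclohexyl to 4-butylcyclohexyl thus leaves the number within the scatter, so this position takes the butyl chain with no difference that can be told apart in this test. Nothing at hand bears on why the number holds, and no cause is offered.

From the compounds shown here alone, whether a longer chain than butyl, or an amine or a carboxylic acid at this position, would read the same remains open. All four numbers lie within the scatter of one another, so what would move the read-out in this test is also still unknown.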